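The source may hold more compounds than are shown below. What is called first, only, known or untested is meant among the compounds shown, and "the series" means these compounds.

Compound 1 `C/C(=C\CC/C(C)=C/CC[C@@H]1[C@@]2(C)CCC(=O)C(C)(C)[C@H]2CC[C@@]1(C)O)CC/C=C(\C)C(=O)OCc1cn(-c2ccc(F)cc2)nn1` gives > 150000 nM in a functional assay on DU-145 cells (Homo sapiens) for antiproliferative activity, read by MTT assay, with a stated time of 48 h (a lower number here means a stronger inhibitor, a higher number a weaker inhibitor), which is a limit of the assay.
Compound 2 `C/C(=C\CC/C(C)=C/CC[C@@H]1[C@@]2(C)CCC(=O)C(C)(C)[C@H]2CC[C@@]1(C)O)CC/C=C(\C)C(=O)OCc1cn(-c2ccccc2C(F)(F)F)nn1` gives > 150000 nM in this assay, again a limit.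
Compound 3 `C/C(=C\CC/C(C)=C/CC[C@@H]1[C@@]2(C)CCC(=O)C(C)(C)[C@H]2CC[C@@]1(C)O)CC/C=C(\C)C(=O)OCc1cn(-c2cccc([N+](=O)[O-])c2)nn1` gives > 150000 nM in this assay, also a limit.

Compound 1 therefore stands at the limit, and nothing separates it from the other two, all three sitting at the limit of > 150000 nM in this assay, at which 3 of the 3 values shown sit. The step to compound 4 `C/C(=C\CC/C(C)=C/CC[C@@H]1[C@@]2(C)CCC(=O)C(C)(C)[C@H]2CC[C@@]1(C)O)CC/C=C(\C)C(=O)OCc1cn(-c2cccc(F)c2)nn1` changes (3-fluorophenyl in place of 4-fluorophenyl on an aromatic nitrogen). Within the data shown here, the measured steps a step that the two limits leave unreadable from compound 1 to compound 2, a step that the two limits leave unreadable from compound 1 to compound 3 and a step that the two limits leave unreadable from compound 2 to compound 3 bear on this change, yet their sizes cannot be read; they show only that varying the group on the aromatic nitrogen left every compound at the limit. He accordingly expects the step that the limit leaves unreadable from compound 1 to compound 4 to stay within the scatter. Compound 4 is estimated at 200000 nM, between 100000 nM and 500000 nM.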

Compound 4, half-maximal inhibitory concentration: > 150000 nM
Compound 4: only a limit was reported (the forecaster's own chance of this, stated with the estimate: 85%); the middle value does not contradict the limit.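

Compound 4 also sits at a limit of the assay, so none of its steps from compound 1, compound 2 or compound 3 can be read: the limit of > 150000 nM in this assay, at which 4 of the 4 values shown sit. The compounds shown leave open whether any group on the aromatic nitrogen would give a readable value in this assay.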